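A methoxy group added to a core tolerated by cells

A few compounds are considered here, and "the series" means these few. Any claim that something is new, unique, unknown or untested is made for them only; others in the source may bear on it.

Compound 1 `NC(=O)c1sc2nc(-c3ccccc3)cc(C(F)(F)F)c2c1N` carries a phenyl ring, a trifluoromethyl group and a primary amide on the shared core. In an ADME assay on Huh-7 cells (Homo sapiens) for cytotoxicity, read by MTT assay, with a stated time of 72 h (a higher number here means that more compound is tolerated, a lower number that less compound is tolerated), compound 1 gives > 20000 nM, which is a limit of the assay rather than a number. Compound 2 `CCOC(=O)c1sc2nc(-c3ccccc3)cc(C(F)(F)F)c2c1N`, with ethoxy in place of amino on a carbonyl carbon, gives in this assay > 20000 nM, likewise a limit. The step that the two limits leave unreadable from compound 1 to compound 2 cannot be read, since (the limit of > 20000 nM in this assay, at which 2 of the 2 values shown sit). Compound 3 `COc1cccc(-c2cc(C(F)(F)F)c3c(N)c(C(N)=O)sc3n2)c1` differs from compound 1 by methoxy in place of hydrogen on an aromatic carbon, that is, phenyl to 3-methoxyphenyl. For the measured compounds named here, no measured step bears directly on this change, and the only step available is unreadable. Compound 3 is therefore expected to remain at the limit as well, with a step that the limit leaves unreadable from compound 1 to compound 3 not beyond the scatter. The estimate for compound 3 is 30000 nM, ranging from 12000 nM to 100000 nM.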

Compound 3, half-maximal cytotoxic concentration: > 20000 nM
Compound 3: no number, only a limit; the forecaster's own chance of this, stated with the estimate: 75%; the middle value is on the limit's open side.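

For the compounds shown here, compound 3, like compound 1, stands only at a limit, so no step between them can be read, since every value sits there: the limit of > 20000 nM in this assay, at which 3 of the 3 values shown sit. The compounds shown leave open how compound 1, compound 2 and compound 3 truly compare in this assay.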